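Extending the amide substituent within the shared core

The source may report more compounds than this note shows. Statements on the series, on what has been measured and on what is new or still open speak of the compounds shown alone.

Measured so far in a functional assay on the whole organism (aorta) with Rattus norvegicus as the target; on this read-out higher numbers stand for larger maximal responses and lower numbers for smaller maximal responses:
compound 1 `CNC(=O)C1=CC(C)(C(F)(F)F)Oc2ccc([N+](=O)[O-])cc21` gives 61.7%
compound 2 `CNC(=O)C1=CC(C(F)(F)F)(C(F)(F)F)Oc2ccc([N+](=O)[O-])cc21` gives 57.9%
compound 3 `CC1(CF)C=C(/C(S)=N\CCC#N)c2cc([N+](=O)[O-])ccc2O1` gives 59.6%

Among the compounds with values here, compound 2 cannot be separated from compound 1 or compound 3 within the scatter; the only measured step reaching it, a number 3.8 percentage points lower from compound 1 to compound 2 (within the scatter), stayed within the scatter, and its gap to compound 3 is smaller still. Compound 4 `N#CCCNC(=O)C1=CC(C(F)(F)F)(C(F)(F)F)Oc2ccc([N+](=O)[O-])cc21` differs from compound 2 by cyanomethyl in place of hydrogen on a saturated chain carbon bound to an amide-type nitrogen. Within the data shown here, no measured step covers this change; the one step recorded concerns a ring substituent, not the amide chain. Compound 3, which also bears a nitrile-terminated chain, sits close to compound 2. The expectation is therefore no step beyond the scatter, a number 0.1 percentage points higher from compound 2 to compound 4 (within the scatter). Compound 4 is estimated at 58%, range 48% to 68%.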

Compound 4, intrinsic activity: the largest response reached, in percent of the reference agonist's: 64.1%
The estimate for compound 4 lay 6.1 percentage points below the measured number; the measured number falls inside the stated range.
By their numbers in this assay, from the lowest: compounds 2, 3, 1 and 4 (each within the scatter of the next).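

In this assay, methylcarbamoyl to (2-cyanoethyl)carbamoyl gives a number 6.2 percentage points higher from compound 2 to compound 4 (within the scatter), so this amide chain position takes the added cyanomethyl without a step beyond the scatter. Within the data shown here, the only other recorded step concerns a ring substituent, which leaves this as the sole reading on the amide chain. No measured property bears on this result, so it remains without an explanation.

Still open, going by these compounds, is whether an amine, a carboxylic acid or a longer chain in place of the nitrile-bearing chain would also stay within the scatter. The same chain on the core of compound 1 also remains to be read.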